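A Benzyloxy Group in Place of Butoxy on Compound 2

This account rests on a few compounds, and the source may have more. Where it says the series, first, only, none or still open, it means among the compounds named here.

Three compounds have been measured in a functional assay on Daoy cells (Homo sapiens) for antiproliferative activity, read by trypan blue exclusion and crystal violet staining, with a stated time of 72 h; a lower number here means a stronger inhibitor, a higher number a weaker inhibitor:
compound 1 `CCCC(=O)NC(c1ccc(C)cc1)c1cc(Cl)c2cccnc2c1O` gives 100 nM
compound 2 `CCCCOc1ccnc2c(O)c(CNC(=O)C3CCCCC3)ccc12` gives 510 nM
compound 3 `CCCC(=O)NC(c1ccccc1)c1cc(Cl)c2cccnc2c1O` gives 110 nM

Compound 2 has the highest number of the three, and both gaps to it lie beyond the scatter: compound 3 is the nearest, compound 1 the furthest. Compound 2 is therefore the weakest inhibitor among the measured set.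

The unmeasured compound 4 `O=C(NCc1ccc2c(OCc3ccccc3)ccnc2c1O)C1CCCCC1` differs from compound 2 in a single place: phenyl in place of propyl on a saturated chain carbon bound to an oxygen on an aromatic ring.

For the measured compounds named here, the only step measured within this set is a 1.1-fold higher number from compound 1 to compound 3 (0.04 log units; within the scatter), a change at a different part of the molecule that does not involve the chain on the oxygen. Going by the values given here, no measured pair shows what happens when a phenyl stands in place of a propyl at that position, so no step on record bears directly on the change from compound 2 to compound 4. Without such guidance, the expected movement in this assay is small, and its direction uncertain. The estimate for compound 4 is 350 nM, in the range 120 nM to 1000 nM. This corresponds to an expected step of a 1.5-fold lower number from compound 2 to compound 4 (0.16 log units; within the scatter), which may well fall within the scatter.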

Compound 4, half-maximal inhibitory concentration: 260 nM
For compound 4 the middle estimate is 1.3-fold (0.13 log units) above the measured one; the range from low to high includes it.
By their numbers in this assay, from the lowest: compounds 1 and 3 (each within the scatter of the next); then compounds 4 and 2 (each within the scatter of the next).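

In this assay the change from butoxy to benzyloxy gives a step that stays within the scatter (a 2.0-fold lower number from compound 2 to compound 4 (0.29 log units; within the scatter)), so compound 2 and compound 4 cannot be told apart in this measurement. The earlier compounds shown here said nothing about this position, and this pair gives its first reading: an open propyl of 3 heavy atoms can give way to a phenyl of 6 heavy atoms, a six-membered aromatic ring of carbon only, with no change beyond the scatter. No measurement on hand accounts for this result, so the pair records only what the number did and offers no explanation for it.

A single pair cannot show how far this tolerance extends, and a longer chain such as hexyloxy, or a phenyl carrying a chlorine or a methoxy group, could behave quite differently from benzyloxy. On these data alone, it also remains open whether an amine or a carboxylic acid at the end of the chain would leave the number where it is or move it clearly beyond the scatter.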